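Swapping the chlorophenyl pattern on a piperazine-linked thione

A few compounds are considered here, and "the series" means these few. Any claim that something is new, unique, unknown or untested is made for them only; others in the source may bear on it.

Measured compounds:
Compound 1 `S=c1oc(-c2ccc3c(c2)OCCO3)nn1CN1CCN(C(c2ccccc2)c2ccccc2)CC1`: in a functional assay on HeLa cells (Homo sapiens) for antiproliferative activity, read by MTT assay, with a stated time of 48 h (on this read-out higher numbers stand for weaker inhibition and lower numbers for stronger inhibition), compound 1 reaches only the limit > 50000 nM.
Compound 2 `Cc1ccc(N2CCN(Cn3nc(-c4ccc5c(c4)OCCO5)oc3=S)CC2)c(C)c1`: in this assay compound 2 likewise gives only the limit > 50000 nM.
Compound 3 `S=c1oc(-c2ccc3c(c2)OCCO3)nn1CN1CCN(c2cccc(Cl)c2)CC1`: in this assay compound 3 gives 47200 nM.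

Among the measured compounds shown here, compound 3 is the only one of the three to return a number at all; the other two sit at the limit of > 50000 nM in this assay, at which 2 of the 3 values shown sit, so its position is simply "the one measurable value", and it lies very close to that limit itself.

The unmeasured compound 4 `S=c1oc(-c2ccc3c(c2)OCCO3)nn1CN1CCN(c2ccccc2Cl)CC1` keeps every atom of compound 3 and differs only in how they are joined: 2-chlorophenyl in place of 3-chlorophenyl on an amine nitrogen in a ring. For the measured compounds named here, one measured step touches the same place, the aryl group on the ring nitrogen: an at least 1.0-fold lower number from compound 2 to compound 3 (0.02 log units; that floor lies within the scatter). That step, from a dimethylphenyl to a chlorophenyl, moved nothing beyond the scatter, and both neighbours of compound 3 in the series stop at the limit. Nothing in these data suggests that moving the chlorine on the phenyl ring will change the read-out beyond the scatter, so the expected step is a 1.1-fold higher number from compound 3 to compound 4 (0.03 log units; within the scatter), essentially flat.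

Compound 4 is therefore expected to give about 50000 nM, between 20000 nM and 150000 nM, with a real chance that only a limit is reported.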

Compound 4, half-maximal inhibitory concentration: 37400 nM
For compound 4 the middle estimate is 1.3-fold (0.13 log units) above the measured one; measured number inside the range.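

Moving the chlorine from the 3-chlorophenyl to the 2-chlorophenyl arrangement gives a 1.3-fold lower number from compound 3 to compound 4 (0.10 log units; within the scatter) in this assay. At this place on the ring nitrogen, the position of the chlorine on the phenyl ring therefore makes no difference that these measurements can resolve, at least for these two arrangements and at this very weak level of inhibition. Replacing the 2,4-dimethylphenyl group adds little more, since that comparison reads an at least 1.3-fold lower number from compound 2 to compound 4 (0.12 log units; that floor lies within the scatter), and the values leave little room to see a change in either direction: the limit of > 50000 nM in this assay, at which 2 of the 4 values shown sit.

The compounds shown do not tell whether a 4-chlorophenyl group, which would complete the set of chlorine positions, would also stay level with these two, or whether a fluorophenyl or methoxyphenyl group would depart from them. Nor do they show whether a pyridine ring or a simple alkyl chain on the same nitrogen, or any change to the shared core, could bring inhibition down to a range where differences between such groups become readable.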